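The compounds below may be only part of what the source reports. "The series", "measured", "known", "first", "only" and "open" are said of these compounds alone.

In a functional assay on the whole organism (Tail, strain ICR) with Mus musculus as the target, in the tail flick test, with a stated time of 90 min, at a dose of 25 umol/kg by the oral route (a higher number here means a stronger effect of the compound at the dose given, a lower number a weaker effect), compound 2 `N=C(N)NCCC[C@H](NC(=O)CN(c1nc(Cl)nc2[nH]cnc12)C1CC1)C(=O)OCc1ccccc1` gives 30.4%, the highest of the two numbers shown. Its nearest neighbour, compound 1 `C[C@@H](O)[C@H](NC(=O)CN(c1nc(Cl)nc2[nH]cnc12)C1CC1)C(=O)OCc1ccccc1`, gives 29.9% in this assay, and the step of a number 0.5 percentage points higher from compound 1 to compound 2 (within the scatter) lies within the scatter. Compound 3 `NCCCC[C@H](NC(=O)CN(c1nc(Cl)nc2[nH]cnc12)C1CC1)C(=O)OCc1ccccc1` differs from compound 2 by a group of 2 heavy atoms (1 carbon, 1 nitrogen; no ring) in place of a group of 4 heavy atoms (1 carbon, 3 nitrogen; no ring), on a saturated chain carbon, four bonds along the chain from an amide-type nitrogen and a carbonyl carbon. For the measured compounds named here, only the step from compound 1 to compound 2 bears on this change, and it was small, so no step beyond the scatter is expected in this assay. For compound 3 the expected value is 30%, with a range from 15% to 45%. That amounts to an expected step of a number 0.4 percentage points lower from compound 2 to compound 3 (within the scatter).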

Compound 3, a percentage reported as activity, at one dose (the size of the read-out at that dose, not a potency): 35.3%
The estimate for compound 3 lay 5.3 percentage points below the measured number; the measured number falls inside the stated range.
By their numbers in this assay, from the lowest: compounds 1, 2 and 3 (each within the scatter of the next).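

Swapping the terminal group on the side chain, with aminomethyl entering on a saturated chain carbon, four bonds along the chain from an amide-type nitrogen and a carbonyl carbon, gives a step within the scatter in this assay (a number 4.9 percentage points higher from compound 2 to compound 3 (within the scatter)). The wider change, 4-aminobutyl in place of 1-hydroxyethyl, also stays within the scatter (a number 5.4 percentage points higher from compound 1 to compound 3 (within the scatter)), so all three side chains remain indistinguishable at this dose. From the compounds shown here alone, whether a carboxylic acid or a plain alkyl chain at this position would separate from them remains open. No evidence on why these numbers fall as they do is available.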